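The compounds below may be only part of what the source reports. "The series", "measured", "known", "first", "only" and "open" are said of these compounds alone.

Measured so far:
- compound 1, `NCCCc1c[nH]c2c(F)cccc12`, in an assay on isolated protein for inhibition of Myeloperoxidase (Homo sapiens), read by ELISA, with a stated time of 5 min (a higher number here means a weaker inhibitor, a lower number a stronger inhibitor), gives 26 nM
- compound 2, `CNC(=O)CCCc1c[nH]c2ccc(F)cc12`, in this assay gives 95 nM
- compound 3, `NCCSCCCc1c[nH]c2c(F)cccc12`, in this assay gives > 100 nM

The value of compound 3 is a limit of the assay, not a number (the limit of > 100 nM in this assay, at which 1 of the 3 values shown sits). Of the two numbers shown, compound 2 has the highest; its nearest neighbour is compound 1, whose number is lower by a margin beyond the scatter.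

Compound 4, `CCSCCc1c[nH]c2ccc(F)cc12`, is not yet measured. It differs from compound 2 in one place: ethylsulfanyl in place of (methylcarbamoyl)methyl on a saturated chain carbon, two bonds along the chain from an aromatic carbon. Within the data shown here, the only step measured is an at least 3.8-fold higher number from compound 1 to compound 3 (0.58 log units; beyond the scatter), which put a sulfur-containing chain onto the amine end of compound 1 and ran to the limit of the assay. Among the measured compounds shown here, that step sits at a different place and swaps different groups, so it bears only loosely on the present change; still, it is the one precedent for bringing a thioether into this series, and it went upward by at least a modest margin.

On that basis compound 4 is expected to land somewhat higher than compound 2, with a real chance that only a limit is returned, so the estimated step is a 2.1-fold higher number from compound 2 to compound 4 (0.32 log units; beyond the scatter). The expected value for compound 4 in this assay is 200 nM, within a range from 70 nM to 600 nM.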

Compound 4, half-maximal inhibitory concentration: > 100 nM
Compound 4: no number, only a limit (the forecaster's own chance of this, stated with the estimate: 45%); the middle value does not contradict the limit.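

In this assay compound 4 gives > 100 nM, a limit of the assay and not a number. Going by these compounds, the step is an at least 1.0-fold higher number from compound 2 to compound 4 (0.02 log units; that floor lies within the scatter), so the swap of (methylcarbamoyl)methyl for ethylsulfanyl on a saturated chain carbon, two bonds along the chain from an aromatic carbon, has no measured size: the floor does not separate the two compounds, and how far compound 4 lies beyond it stays unknown. The new point is that a thioether at this place, with no amide left on the chain, also fails to return a number, so neither sulfur-bearing compound shown, compound 3 or compound 4, gives one in this assay: the limit of > 100 nM in this assay, at which 2 of the 4 values shown sit.

The swap removes the amide and brings in sulfur in one change, and the compounds shown cannot tell those two parts apart. A primary amine or a carboxylic acid on the chain of the core of compound 2, or an ethoxy group in place of ethylsulfanyl at this same place, would show whether this position tolerates anything beyond the amide of compound 2.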